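Growth inhibition series: methoxy for chloro in compound 4

This account rests on a few compounds, and the source may have more. Where it says the series, first, only, none or still open, it means among the compounds named here.

Measured compounds:
compound 1 `O=C(OC/C(=C/c1ccc(Cl)cc1Cl)C(=O)c1ccccc1)c1ccccc1` — in a functional assay on T47D cells (Homo sapiens) for inhibition, read by sulforhodamine B assay, with a stated time of 48 h (a higher number here means a weaker inhibitor of growth, a lower number a stronger inhibitor of growth), compound 1 gives 5400 nM
compound 2 `CC(=O)OC/C(=C/c1ccc(Cl)cc1)C(=O)c1ccc(Cl)cc1` — in this assay compound 2 gives 12000 nM
compound 3 `C=C(C/C(=C\c1ccc(Cl)cc1)C(=O)c1ccccc1)C(=O)c1ccccc1` — in this assay compound 3 gives 19000 nM

Compound 3 holds the highest of the three numbers in this assay. Its gap to compound 2 lies within the usual scatter, so the two cannot be ordered against each other; its gap to compound 1 lies beyond the scatter, so compound 1 is the stronger inhibitor of growth of that pair. Among the compounds with values here, no two measured compounds differ in a single place, so no measured step bears on the change at hand.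

Compound 4 `C=C(C/C(=C\c1ccc(OC)cc1)C(=O)c1ccccc1)C(=O)c1ccccc1` differs from compound 3 in one place: methoxy in place of chloro on an aromatic carbon. The shared core of compound 3 is otherwise kept. Nothing measured here speaks to this exchange, so in this assay the expected step is small and of no firm direction. The expected step is a 1.2-fold higher number from compound 3 to compound 4 (0.06 log units; within the scatter). Compound 4 is thus estimated at 22000 nM in this assay, within a range from 8000 nM to 60000 nM.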

Compound 4, concentration for 50% growth inhibition: 370 nM
Compound 4: middle estimate off by 59-fold (1.77 log units), on the high side, outside the stated range (below it).
By their numbers in this assay, from the lowest: compound 4; then compound 1; then compounds 2 and 3 (each within the scatter of the next).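

In this assay, the exchange of 4-chlorophenyl for 4-methoxyphenyl gives a 51-fold lower number from compound 3 to compound 4 (1.71 log units; beyond the scatter), so growth inhibition in this pair responds strongly to the group at this one position, with the rest of the shared core kept. The earlier compounds shown here differ from one another in more than one place and could not show the effect of any single position. No measurement here bears on why the step has this size.

Whether the step belongs to methoxy itself stays open, since a hydroxyl, an ethoxy or a dimethylamino group at this position is not among the compounds shown. Also open, on these data alone, is whether the same exchange gives a step of this size on the core of compound 2, with its acetate ester.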